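Swapping the benzyl group on a naphthyl cyanoacrylamide

The compounds below may be only part of what the source reports. "The series", "measured", "known", "first", "only" and "open" are said of these compounds alone.

Measured so far:
- compound 1 `COc1ccc(CNC(=O)/C(C#N)=C/c2ccc(-c3ccccc3)o2)cc1`: > 100000 nM
- compound 2 `COc1ccc(CNC(=O)/C(C#N)=C/c2cccc3ccccc23)cc1`: 15000 nM

Both compounds were tested in a functional assay on SMA cells (Homo sapiens) for inhibition, read by MTT assay, with a stated time of 72 h; a higher number here means a weaker inhibitor of growth, a lower number a stronger inhibitor of growth. Compound 1 reached only the limit of the assay, > 100000 nM, so no number is known for it. Going by the values given here, compound 2 gives 15000 nM in this assay, and it is the only real number among the two results. The result for compound 1 is a limit, as the limit of > 100000 nM in this assay, at which 1 of the 2 values shown sits, shows. Compound 2 therefore stands alone as the reference point.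

Compound 3 `N#C/C(=C\c1cccc2ccccc12)C(=O)NCc1ccc(Cl)c(Cl)c1` is the next compound to be measured. It differs from compound 2 in one place only: 3,4-dichlorophenyl in place of 4-methoxyphenyl on a saturated chain carbon bound to an amide-type nitrogen. Among the compounds with values here, no measured pair shows the effect of this particular change, so the expectation rests on compound 2 alone. The step is expected to be modest, with compound 3 estimated to be somewhat stronger than compound 2, as in a 1.9-fold lower number from compound 2 to compound 3 (0.27 log units; within the scatter). Compound 3 is estimated at 8000 nM in this assay, within a range from 2000 nM to 40000 nM.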

Compound 3, concentration for 50% growth inhibition: 7000 nM
Compound 3: middle estimate off by 1.1-fold (0.06 log units), on the high side; the range from low to high includes it.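

Replacing 4-methoxyphenyl with 3,4-dichlorophenyl on a saturated chain carbon bound to an amide-type nitrogen gives a 2.1-fold lower number from compound 2 to compound 3 (0.33 log units; beyond the scatter) in this assay. Going by these compounds alone, this is the first measured change in one place, and it shows that this position can take a different aryl group with the same heavy-atom count, one with no hydrogen-bond acceptor, without losing growth inhibition; the step is modest, but it does go in the stronger direction. Nothing given here bears on why the number moved.

The two compounds cannot show whether the step comes from losing the methoxy group or from gaining the chlorines. An unsubstituted phenyl or a 4-chlorophenyl at this place would separate those two parts, while a pyridine ring would test whether a ring nitrogen is accepted there.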